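The source may hold more compounds than are shown below. What is called first, only, known or untested is meant among the compounds shown, and "the series" means these compounds.

Series notes. Compound 1 `COCOc1cc(C#Cc2cc(OC)c(OC)c(OC)c2)ccc1OC` and compound 2 `COCOc1cc(/C=C\c2cc(OC)c(OC)c(OC)c2)ccc1OC` differ in their cores; the difference between the two cores is not broken down here. In a functional assay on HeLa cells (Homo sapiens) for cytotoxicity, read by MTT assay (a higher number here means a weaker inhibitor, a lower number a stronger inhibitor), compound 1 gives 26800 nM. In this assay compound 2 gives 197 nM, the lowest of the two numbers. Compound 3 `COc1ccc(C#Cc2cc(OC)c(OC)c(OC)c2)cc1NC(=O)OC(C)(C)C` arises from compound 1 by (tert-butoxycarbonyl)amino in place of methoxymethoxy on an aromatic carbon. In this assay compound 3 reports only a limit, > 30000 nM. The resulting step is an at least 1.1-fold higher number from compound 1 to compound 3 (0.04 log units; that floor lies within the scatter), a floor only, because the value sits at the limit of > 30000 nM in this assay, at which 1 of the 3 values shown sits. Compound 4 `COc1ccc(/C=C\c2cc(OC)c(OC)c(OC)c2)cc1NC(=O)OC(C)(C)C` carries the same change on compound 2, ((tert-butoxycarbonyl)amino in place of methoxymethoxy on an aromatic carbon). The expected step is a 15-fold higher number from compound 2 to compound 4 (1.18 log units; beyond the scatter). This rests on the measured step being open-ended upward, since compound 3 shows only (the limit of > 30000 nM in this assay, at which 1 of the 3 values shown sits), so a larger loss than the floor is taken as likely. In this assay compound 4 is estimated at 3000 nM, between 500 nM and 30000 nM.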

Compound 4, half-maximal inhibitory concentration: 1170 nM
Compound 4: middle estimate off by 2.6-fold (0.41 log units), on the high side; low and high end bracket the measured number.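

In this assay, (tert-butoxycarbonyl)amino in place of methoxymethoxy on the core of compound 2 gives a 5.9-fold higher number from compound 2 to compound 4 (0.77 log units; beyond the scatter), so the change weakens inhibition on this core. Set beside the same change on the core of compound 1, the two steps read: the same change on two cores in this assay, an at least 1.1-fold higher number (0.04 log units; that floor lies within the scatter) from compound 1 to compound 3 and a 5.9-fold higher number (0.77 log units; beyond the scatter) from compound 2 to compound 4; the limit leaves it open whether they differ. Compound 3 reports a limit and not a number, so the size of the step on the core of compound 1 stays unknown and equal transfer between the cores is neither shown nor excluded: the limit of > 30000 nM in this assay, at which 1 of the 4 values shown sits.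

The compounds shown leave open how a free amine or an acetamide in place of methoxymethoxy would read on either core. From the compounds shown here alone, whether the direction of the step holds on any further core also stays open.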